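The compounds below may be only part of what the source reports. "The series", "measured", "known", "first", "only" and "open" are said of these compounds alone.

Compound 1 `CCCCCCCC#Cc1cc2cn(COCCO)c(=O)nc2o1`: 200000 nM in a functional assay on HEL cells (Homo sapiens), read by microscopy; a higher number here means that more compound is tolerated, a lower number that less compound is tolerated
Compound 2 `CCCCCCCCCCc1cc2cn(COCCO)c(=O)nc2o1`: 400000 nM in this assay
Compound 3 `CCCCCC#Cc1cc2cn(COCCO)c(=O)nc2o1`: a limit of this assay, >= 100000 nM

In this assay compound 1 and compound 2 lie within the scatter of each other, so no order is read between them. The difference between the two cores of compound 1 and compound 2 is not broken down here. Compound 3 differs from compound 1 by hydrogen in place of ethyl on a saturated chain carbon, five bonds along the chain from a triple-bonded carbon, and the step that the limit leaves unreadable from compound 1 to compound 3 stays unreadable because of the limit of >= 100000 nM in this assay, at which 1 of the 3 values shown sits.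

Compound 4 `CCCCCCCCc1cc2cn(COCCO)c(=O)nc2o1` is not yet measured and differs from compound 2 by hydrogen in place of ethyl on a saturated chain carbon, eight bonds along the chain from an aromatic carbon. This is the same kind of change as from compound 1 to compound 3, but the place differs: five bonds along the chain from a triple-bonded carbon there, eight bonds along the chain from an aromatic carbon here. Since the measured step of this kind is unreadable, the expectation rests on compound 2 at 400000 nM, with a step estimated as a 1.3-fold lower number from compound 2 to compound 4 (0.12 log units; within the scatter). Compound 4 is expected near 300000 nM, between 100000 nM and 1000000 nM.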

Compound 4, minimum cytotoxic concentration: >= 80000 nM
Compound 4: no number, only a limit; the forecaster's own chance of this, stated with the estimate: 40%; the middle value does not contradict the limit.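

In this assay compound 4 gives only a limit of >= 80000 nM and so no new step can be read from compound 2 to compound 4. The compounds shown leave open whether in this assay hydrogen in place of ethyl on a saturated chain carbon moves the number at all.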